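Swapping the amide aryl group of a hydrazone growth inhibitor

The compounds below may be only part of what the source reports. "The series", "measured", "known", "first", "only" and "open" are said of these compounds alone.

Measured compounds:
Compound 1, `COc1cc(/C=N\NC(=O)C2=C(Cl)c3cc(C)c(C)cc3CCC2)cc(OC)c1OC`: 21000 nM
Compound 2, `O=C(N/N=C/C1=C(Cl)c2ccccc2CCC1)c1cccnc1`: 7500 nM
Compound 3, `COc1cccc(C(=O)N/N=C/C2=C(Cl)c3cc(C)c(C)cc3CCC2)c1C`: 300 nM

Three compounds sharing a chlorinated bicyclic core linked through a hydrazone to an aryl amide were tested in a functional assay on HeLa cells (Homo sapiens) for inhibition, read by sulforhodamine B assay, with a stated time of 48 h; a higher number here means a weaker inhibitor of growth, a lower number a stronger inhibitor of growth. Compound 3 gives the lowest number of the three in this assay. Its nearest neighbour is compound 2, and its furthest is compound 1; both gaps lie beyond the usual scatter, so compound 3 stands apart as the strongest growth inhibitor among the measured compounds.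

Compound 4, `Cc1cc2c(cc1C)C(Cl)=C(/C=N/NC(=O)c1cccc(I)c1)CCC2`, has not yet been measured. It differs from compound 3 in one place: 3-iodophenyl in place of 3-methoxy-2-methylphenyl on a carbonyl carbon. Among the measured compounds shown here, no pair of measured compounds shows exactly this kind of exchange, so no measured step can guide the expectation directly. The measured set only shows that the aryl amide part matters, since compound 3, compound 2 and compound 1 differ widely in this assay. For compound 4 the expected step is a 3.3-fold higher number from compound 3 to compound 4 (0.52 log units; beyond the scatter), a modest weakening in this assay. The estimate for compound 4 is 1000 nM, with a range from 200 nM to 5000 nM.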

Compound 4, concentration for 50% growth inhibition: > 100000 nM
Compound 4 gave a limit, no number; the forecaster's own chance of this, stated with the estimate: 5%; middle value at least 100-fold (2.00 log units) from the limit.
By their numbers in this assay, from the lowest: compound 3; then compound 2; then compound 1. At a limit, above all of these: compound 4.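

On the carbonyl carbon, the choice of aryl group can separate clear growth inhibition from a result that does not reach a number in this assay: 3-iodophenyl in place of 3-methoxy-2-methylphenyl gives an at least 330-fold higher number from compound 3 to compound 4 (2.52 log units; beyond the scatter). The reading for compound 4 is a limit, not a number: the limit of > 100000 nM in this assay, at which 1 of the 4 values shown sits. This is the only step shown that changes a single place, so it ties a large change to this exchange in a way the earlier compounds could not.

The exchange removes the methoxy and methyl groups and brings in iodine all at once, so the data cannot say which of these changes matters. From the compounds shown here alone, it also remains open whether a phenyl ring carrying only a methoxy group, or one carrying an amine, would keep the growth inhibition of compound 3.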